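This account rests on a few compounds, and the source may have more. Where it says the series, first, only, none or still open, it means among the compounds named here.

Working notes on the series, in a physicochemical assay for solubility, read by LC-MS, in phosphate buffer, with a stated time of 24 h, at pH 7.4; a lower number here means a less soluble compound, a higher number a more soluble compound.

Compound 1 `O=C(Nc1ccccc1)c1cnc(NCc2c(F)ccc3c2CCO3)n2cnnc12` has only a limit in this assay: compound 1 gives < 1000 nM, and that value is the reporting limit, not a measured number; it is the case described by the limit of < 1000 nM in this assay, at which 1 of the 3 values shown sits. The two compounds of the series with measured numbers stand well apart from that limit. Compound 2 `CN(C)Cc1ccc2c(c1)CN(c1cnc(NCc3c(F)ccc4c3CCO4)c3cn[nH]c(=O)c13)C2=O` gives 174000 nM in this assay. Compound 3 `CNC(=O)c1ncc(-c2cnc(NCc3c(F)ccc4c3CCO4)c3cn[nH]c(=O)c23)n1C` gives 5000 nM in this assay. Among the measured compounds shown here, both share the fluorinated dihydrobenzofuranylmethylamino side chain with compound 1 but carry a different core, so no single-change step to compound 1 exists among them.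

Compound 4 `O=C(Nc1cnc(NCc2c(F)ccc3c2CCO3)n2cnnc12)c1cccnc1` is not yet measured. It differs from compound 1 by ((pyridin-3-yl)carbonyl)amino in place of phenylcarbamoyl on an aromatic carbon. For the measured compounds named here, no measured step of this kind exists, so the size of the change can only be guessed. The expected step from compound 1 to compound 4 is an at least 2.0-fold higher number from compound 1 to compound 4 (0.30 log units; that floor lies within the scatter), a modest rise, possibly no more than the scatter. Compound 4 is therefore expected to give about 2000 nM in this assay, with a range from 500 nM to 8000 nM, and a fair chance that only a limit is reported again.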

Compound 4, solubility: 12000 nM
Beside the measured number, compound 4's estimate is 6.0-fold (0.78 log units) below it; measured number outside the range, above it.
By their numbers in this assay, from the lowest: compound 3; then compound 4; then compound 2. At a limit, below all of these: compound 1.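

In this assay, among the compounds shown here, the replacement of phenylcarbamoyl by ((pyridin-3-yl)carbonyl)amino on an aromatic carbon of the shared core gives an at least 12-fold higher number from compound 1 to compound 4 (1.07 log units; beyond the scatter), the first step that can be read at a single place and one that lies beyond the scatter. Compound 1 gives < 1000 nM, which is a limit of the assay and not a number. The step is therefore a floor, and its true size remains unknown: the limit of < 1000 nM in this assay, at which 1 of the 4 values shown sits.

The change brings a ring nitrogen and a reversed amide link together, and the compounds shown do not separate the two. Also open, going by these compounds, is how a morpholine or a carboxylic acid on this same aromatic carbon would read in this assay.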